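The compounds below may be only part of what the source reports. "The series", "measured", "known", "first", "only" and "open" are said of these compounds alone.

Measured so far in an ADME assay on a cell-free system (plasma, Mus musculus) for metabolic stability, read by LC-MS, tested at 2 uM; on this read-out higher numbers stand for a longer-lived compound and lower numbers for a shorter-lived compound:
- compound 1 `O=C(NCCCCc1ccccc1)n1cc(-c2ccc(F)cc2)oc1=O`: 1.5 h
- compound 2 `O=C(NCCCCc1ccccc1)n1cc(-c2cccnc2)oc1=O`: 1 h

Going by the values given here, compound 1 and compound 2 are the only two numbers available, and they lie within the scatter of each other. Compound 3 `CN1CCC(c2cc(F)ccc2-c2cn(C(=O)NCCCCc3ccccc3)c(=O)o2)CC1` keeps the core of compound 1 and differs in one place: 1-methylpiperidin-4-yl in place of hydrogen on an aromatic carbon. Among the compounds with values here, the only measured step is a 1.5-fold lower number from compound 1 to compound 2 (0.18 log units; within the scatter). That step exchanges a different group, so it does not test this change directly. Within the data shown here, no measured compound carries 1-methylpiperidin-4-yl, so no step beyond the scatter can be expected in either direction, though the uncertainty is wide. The estimated step is a 1.2-fold lower number from compound 1 to compound 3 (0.06 log units; within the scatter). For compound 3 the expected half-life is 1.3 h, with an estimated range of 0.6 h to 3 h.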

Compound 3, half-life: > 2 h
Compound 3 gave a limit, no number; the forecaster's own chance of this, stated with the estimate: 10%; at least 1.5-fold (0.18 log units) between middle value and limit.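

In this assay, compound 3 gave a limit, not a number: the limit of > 2 h in this assay, at which 1 of the 3 values shown sits.

The earlier compounds shown here carried only hydrogen at this place, ortho to a large group and meta to a fluoro group. Here 1-methylpiperidin-4-yl in its place gives an at least 1.3-fold higher number from compound 1 to compound 3 (0.12 log units; that floor lies within the scatter), so this large ring with its nitrogen leaves no sign of a shorter half-life, although that floor alone shows no real rise.

From the compounds shown here alone, how far compound 3 truly lies from compound 1 stays open. So does whether a smaller amine, such as dimethylamino, or a piperidin-4-yl ring without its methyl group would behave alike here.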